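Swapping pyrrolidin-1-yl for (1-phenylethyl)amino on a carbonyl carbon

A few compounds are considered here, and "the series" means these few. Any claim that something is new, unique, unknown or untested is made for them only; others in the source may bear on it.

Measured in a functional assay on U-937 cells (Homo sapiens) for antiproliferative activity, read by MTT assay, with a stated time of 24 h; a lower number here means a stronger inhibitor, a higher number a weaker inhibitor:

- compound 1 `CCCCc1oc2ccccc2c1C(=O)c1ccc(OCC(N)=O)cc1` gives 42200 nM
- compound 2 `CCCCc1oc2ccccc2c1C(=O)c1ccc(OCC(=O)N2CCOCC2)cc1` gives 45400 nM
- compound 3 `CCCCc1oc2ccccc2c1C(=O)c1ccc(OCCCC(=O)N2CCCC2)cc1` gives 7500 nM

Compound 3 has the lowest number of the three, at 7500 nM. The numbers for the other two lie within the scatter of each other, and both lie clearly above it, as a 5.6-fold lower number from compound 1 to compound 3 (0.75 log units; beyond the scatter) and a 6.1-fold lower number from compound 2 to compound 3 (0.78 log units; beyond the scatter) show. Compound 4 `CCCCc1oc2ccccc2c1C(=O)c1ccc(OCCCC(=O)N[C@H](C)c2ccccc2)cc1` has not yet been measured. It differs from compound 3 only at the amide: (1-phenylethyl)amino in place of pyrrolidin-1-yl on a carbonyl carbon.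

Within the data shown here, the closest precedent is a 1.1-fold higher number from compound 1 to compound 2 (0.03 log units; within the scatter), where morpholin-4-yl took the place of amino on a carbonyl carbon. Among the measured compounds shown here, this is the only measured step confined to that position, and it made no visible difference. The two modest steps to compound 3 also alter the saturated chain, so they say little about this swap. For the measured compounds named here, no measured compound carries the entering group, which leaves the direction open and the uncertainty wide. The expected outcome is therefore little or no change, and the estimated step is a 1.2-fold lower number from compound 3 to compound 4 (0.06 log units; within the scatter). For compound 4 the expected value is 6500 nM, with an estimated range of 2500 nM to 17000 nM.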

Compound 4, half-maximal inhibitory concentration: 30700 nM
Compound 4: middle estimate off by 4.7-fold (0.67 log units), on the low side; measured number above the stated range.
By their numbers in this assay, from the lowest: compound 3; then compounds 4, 1 and 2 (each within the scatter of the next).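

In this assay, among these compounds, the position on the carbonyl carbon proves sensitive to what it carries when the saturated chain of compound 3 is kept, with (1-phenylethyl)amino in place of pyrrolidin-1-yl giving a step beyond the scatter (a 4.1-fold higher number from compound 3 to compound 4 (0.61 log units; beyond the scatter)), whereas the only earlier step confined to this position, on a different chain, stayed within it (a 1.1-fold higher number from compound 1 to compound 2 (0.03 log units; within the scatter)). Compound 4 keeps the chain of compound 3 and still loses most of the advantage, so the low number of compound 3 belongs to that chain together with its pyrrolidin-1-yl amide, not to the chain alone. Nothing given here explains why the entering group raises the number.

The change brings in an aromatic ring, an amide hydrogen and a defined stereocentre all at once, so the compounds shown cannot say which of these matters. As far as these compounds go, a benzylamino or piperidin-1-yl group on the same carbonyl, or the opposite stereocentre of the 1-phenylethyl group, would be needed to separate them, and whether any amine on this chain can go lower than pyrrolidine remains open.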